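Trifluoromethyl in place of cyano: an expected rise in lipophilicity

A few compounds are considered here, and "the series" means these few. Any claim that something is new, unique, unknown or untested is made for them only; others in the source may bear on it.

Of the compounds shown here, three sharing one core have been measured in a physicochemical assay for lipophilicity, using the shake flask method, at pH 7.4; on this read-out higher numbers stand for higher lipophilicity and lower numbers for lower lipophilicity. Compound 1 `O=C(O)CCNC(=O)c1ccc(C(Oc2ccc(-n3cc(C(F)(F)F)cn3)cc2)C2CCCC2)cc1` gives 3.3. Compound 2 `CCCC(Oc1ccc(-n2cc(C(=O)N(C)C)cn2)cc1)c1ccc(C(=O)NCCC(=O)O)cc1` gives 0.5. Compound 3 `CCCC(Oc1ccc(-n2cc(C#N)cn2)cc1)c1ccc(C(=O)NCCC(=O)O)cc1` gives 1.2, which places compound 3 second highest of the three numbers, a value that sits a number 0.70 log units higher from compound 2 to compound 3 (beyond the scatter). Going by the values given here, compound 1 lies further away from compound 3, but the two differ in more than one place, so their values show only that the trifluoromethyl-bearing compound 1 is the most lipophilic of the three measured.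

Compound 4 `CCCC(Oc1ccc(-n2cc(C(F)(F)F)cn2)cc1)c1ccc(C(=O)NCCC(=O)O)cc1` differs from compound 3 in one place: trifluoromethyl in place of cyano on an aromatic carbon. Among the compounds with values here, no measured step swaps cyano for trifluoromethyl directly, and the only single-change step on record, from dimethylcarbamoyl to cyano, is of another kind. The comparison therefore rests on the general behaviour of these two groups rather than on a measured pair. On that basis, a step of about a number 1.20 log units higher from compound 3 to compound 4 (beyond the scatter) is expected in this assay, upward and well beyond the scatter. Compound 4 is estimated at 2.4 in this assay, with a likely range from 1.9 to 2.9.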

Compound 4, distribution coefficient: 2.4
The estimate for compound 4 equals the measured number at the digits printed; measured number inside the range.
By their numbers in this assay, from the lowest: compound 2; then compound 3; then compound 4; then compound 1.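

In this assay the group on this aromatic carbon of the five-membered ring can now be compared across three members with the propyl chain held fixed: trifluoromethyl gives a number 1.20 log units higher from compound 3 to compound 4 (beyond the scatter) against the nitrile and a number 1.90 log units higher from compound 2 to compound 4 (beyond the scatter) against dimethylcarbamoyl, so the order runs dimethylcarbamoyl, cyano, trifluoromethyl in these three compounds. Compound 4 also provides the first single-change link to compound 1, and swapping cyclopentyl for propyl on the saturated chain carbon gives a number 0.90 log units lower from compound 1 to compound 4 (beyond the scatter) in the same read-out, which shows that the high number of compound 1 comes from changes at both places and not from trifluoromethyl alone. No measurement shown here explains why the groups fall in this order.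

Where a methyl or a chlorine on the same aromatic carbon would fall on this scale remains open, as does the place of an isopropyl or a cyclobutyl on the chain carbon. Cyano and dimethylcarbamoyl appear here only with the propyl chain, so whether their steps would carry over to a cyclopentyl compound also remains open.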